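Moving the methoxy group on the benzyl ether of a rhodanine

A few compounds are considered here, and "the series" means these few. Any claim that something is new, unique, unknown or untested is made for them only; others in the source may bear on it.

Measured compounds:
compound 1 `O=C1NC(=S)S/C1=C\C=C\c1cc(Br)ccc1OCc1ccccc1Br` gives 40.3% in an assay on isolated protein for inhibition of protein tyrosine phosphatase type IVA 3 (Homo sapiens), tested at 5 ug/mL; on this read-out lower numbers stand for less inhibition and higher numbers for more inhibition at the one concentration tested (going by the name of the read-out)
compound 2 `COc1ccccc1COc1ccccc1/C=C/C=C1\SC(=S)NC1=O` gives 78.8% in this assay

Compound 2 stands highest of the two numbers seen so far; its nearest neighbour is compound 1, whose value is lower by a margin beyond the usual scatter. Among the measured compounds shown here, no step between the two measured compounds is known, since they differ in more than one place.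

Compound 3 `COc1cccc(COc2ccccc2/C=C/C=C2\SC(=S)NC2=O)c1` has not yet been measured in this assay. It differs from compound 2 as follows: 3-methoxyphenyl in place of 2-methoxyphenyl on a saturated chain carbon bound to an oxygen on an aromatic ring. The two compounds hold the same atoms, joined differently. Nothing measured here shows how such a change acts on this read-out. Compound 3 is therefore expected to stay close to compound 2, with a step of a number 8.8 percentage points lower from compound 2 to compound 3 (within the scatter) that may fall within the scatter or slightly below it. The estimate for compound 3 is 70%, expected between 48% and 88%.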

Compound 3, a percentage reported as inhibition, at one concentration (the size of the read-out at that concentration, not a potency): 52.9%
Estimate against measurement, compound 3: 17.1 percentage points above; measured number inside the range.
By their numbers in this assay, from the lowest: compound 1; then compound 3; then compound 2.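

Read in this assay, the swap of 3-methoxyphenyl for 2-methoxyphenyl on a saturated chain carbon bound to an oxygen on an aromatic ring brings a number 25.9 percentage points lower from compound 2 to compound 3 (beyond the scatter) and is the first single change seen in this series. The two compounds hold the same atoms, joined differently, so where the methoxy group sits on this ring is enough on its own to shift the read-out, which compound 1 and compound 2 could not show, as they differ in more than one place. Nothing available gives a reason for this step.

The compounds shown leave open how the read-out responds at this same place to an ethoxy group in place of the methoxy group, or to a carboxylic acid. They also leave open whether moving the methoxy group has a similar effect when the bromine atoms of compound 1 are present.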